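The source may hold more compounds than are shown below. What is called first, only, known or untested is meant among the compounds shown, and "the series" means these compounds.

Compound 1 `COc1ccc(-c2cc(=O)c3c(OC)cc(OC)cc3[nH]2)cc1`: > 31100 nM
Compound 2 `COc1ccc(-c2cc(=O)c3c(OC)cc(OC)cc3n2S(=O)(=O)c2cc(F)c(F)c(F)c2)cc1`: > 65500 nM

In a functional assay on HepG2 cells (Homo sapiens) for antiproliferative activity, with a stated time of 72 h (on this read-out higher numbers stand for an effect only at larger amounts of compound and lower numbers for an effect already at smaller amounts), compound 2 reads > 65500 nM and that is a limit, not a number. Compound 1 reads > 31100 nM and that too is a limit. Compound 3 (`COc1ccc(-c2cc(=O)c3c(OC)cc(OC)cc3n2S(=O)(=O)c2cccc(Br)c2)cc1`) carries 3-bromophenyl in place of 3,4,5-trifluorophenyl on a sulfonyl sulfur. For the measured compounds named here, no measured step shows what such a change does. In this assay the expected shift stays within the usual scatter, an estimated at least 1.3-fold lower number from compound 2 to compound 3 (0.11 log units; that floor lies within the scatter) and no more, in either direction. Compound 3 is estimated at 50000 nM (expected range 12000 nM to 100000 nM).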

Compound 3, half-maximal effective concentration: > 58600 nM
Compound 3 gave a limit, no number (the forecaster's own chance of this, stated with the estimate: 70%); middle value at least 1.1-fold (0.06 log units) away from the limit.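

In this assay, compound 1, compound 2 and compound 3 all read as limits, so neither the step to compound 3 from compound 2 nor that from compound 1 can be read. The compounds shown leave open whether either change shifts the read-out at all.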